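Aryl exchange from compound 2 to compound 3

The source may hold more compounds than are shown below. What is called first, only, known or untested is meant among the compounds shown, and "the series" means these compounds.

Compound 1 `CC1CCN(C2CCN(S(=O)(=O)c3cccc(-c4ccc5ccccc5c4)c3)CC2)CC1`: 3.4 h
Compound 2 `CC1CCN(C2CCN(S(=O)(=O)c3cccc(-c4ccc(F)cc4)c3)CC2)CC1`: 1.28 h

In an ADME assay on S9 fraction from liver (Mus musculus, strain ICR/CD-1) for metabolic stability, read by LC-MS, using NADPH, with a stated time of 5 min, tested at 2 uM (on this read-out higher numbers stand for a longer-lived compound and lower numbers for a shorter-lived compound), compound 2 holds the lower of the two numbers at 1.28 h. Compound 3 `Cc1cc(C)cc(-c2cccc(S(=O)(=O)N3CCC(N4CCC(C)CC4)CC3)c2)c1` carries 3,5-dimethylphenyl in place of 4-fluorophenyl on an aromatic carbon. Within the data shown here, the only measured guide is a modest step, a 2.7-fold lower number from compound 1 to compound 2 (0.42 log units; beyond the scatter), with 4-fluorophenyl replacing naphthalen-2-yl. Among the measured compounds shown here, no measured compound carries 3,5-dimethylphenyl, so that step bears only loosely, and no change beyond the scatter is expected. The expected step is a 1.2-fold higher number from compound 2 to compound 3 (0.07 log units; within the scatter). For compound 3 the estimate is 1.5 h, with an expected range of 0.7 h to 3.2 h.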

Compound 3, half-life: > 4 h
Compound 3 ended at the assay's limit (the forecaster's own chance of this, stated with the estimate: 2%); at least 2.6-fold (0.42 log units) between middle value and limit.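

At this position on the core, a single substituted phenyl ring can match the longest half-life seen: 3,5-dimethylphenyl clearly outlasts 4-fluorophenyl (an at least 3.1-fold higher number from compound 2 to compound 3 (0.49 log units; beyond the scatter)) in this assay. Against naphthalen-2-yl the floor gives no order, so compound 3 cannot be placed above compound 1 (an at least 1.1-fold higher number from compound 1 to compound 3 (0.07 log units; that floor lies within the scatter)). The reading for compound 3 is a limit of the assay, not a number: the limit of > 4 h in this assay, at which 1 of the 3 values shown sits.

From the compounds shown here alone, how far compound 3 lies past that limit remains open. So does the effect of an amine or a carboxylic acid on this phenyl ring.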